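Extending the Side Chain on the Ring Nitrogen of Compound 2

A few compounds are considered here, and "the series" means these few. Any claim that something is new, unique, unknown or untested is made for them only; others in the source may bear on it.

Of the compounds shown here, three sharing one core have been tested in a functional assay for inhibition, with Homo sapiens as the target; a higher number here means a weaker inhibitor, a lower number a stronger inhibitor. Compound 1 `Cc1nc(C)n2c(=O)n(C)ncc12` gives only a limit in this assay, namely > 48000 nM, so no number is known for it. Compound 2 `CCCc1nc(C)c2cnn(C)c(=O)n12` gives 20000 nM in this assay, and compound 3 `CCCc1nn(C)c(=O)n2c(CCC)nc(C)c12` gives 18000 nM. These two numbers cannot be told apart, since a 1.1-fold lower number from compound 2 to compound 3 (0.05 log units; within the scatter). Among the compounds with values here, the one step that reached beyond the scatter is an at least 2.4-fold lower number from compound 1 to compound 2 (0.38 log units; beyond the scatter), a change at a saturated chain carbon bound to an aromatic carbon.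

Compound 4 `CCCc1nc(C)c2cnn(CC(=O)OCC)c(=O)n12` has not yet been measured. It differs from compound 2 in one place: ethoxycarbonyl in place of hydrogen on a saturated chain carbon bound to an aromatic nitrogen. Neither measured step touches a saturated chain carbon bound to an aromatic nitrogen, so neither speaks directly to this change. The step from compound 1 to compound 2 shows that lengthening a small side chain can lower the number, while the step from compound 2 to compound 3 shows that adding a further chain can also leave it unchanged. Compound 4 is therefore expected to sit close to compound 2, at an estimated 15000 nM with a range from 5000 nM to 45000 nM. That estimate means a step of a 1.3-fold lower number from compound 2 to compound 4 (0.12 log units; within the scatter), within the scatter.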

Compound 4, half-maximal inhibitory concentration: > 48000 nM
Compound 4: only a limit was reported; the forecaster's own chance of this, stated with the estimate: 15%; middle value at least 3.2-fold (0.50 log units) away from the limit.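

In this assay, within the data shown here, the change from methyl to (ethoxycarbonyl)methyl gives an at least 2.4-fold higher number from compound 2 to compound 4 (0.38 log units; beyond the scatter), so this position, on which the earlier compounds were silent, does respond to what is attached there, and this change weakens inhibition. Adding to a side chain therefore has no single outcome across the compounds shown: ethyl at a saturated chain carbon bound to an aromatic carbon goes the other way, with an at least 2.4-fold lower number from compound 1 to compound 2 (0.38 log units; beyond the scatter). The value of compound 4 is a limit and not a number, so the step has no upper end, and it is the same limit as the one reported for compound 1: the limit of > 48000 nM in this assay, at which 2 of the 4 values shown sit.

On these data alone, what remains open is which part of the entering ethoxycarbonyl group matters, since this single change adds its carbonyl, its oxygen atoms and its chain length all at once. A plain longer chain, a carboxylic acid or an amine at this same place could begin to separate these parts, but the compounds shown say nothing about any of them.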